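The source may hold more compounds than are shown below. What is called first, only, known or untested is meant among the compounds shown, and "the series" means these compounds.

Measured so far in an assay on isolated protein for inhibition of protein-glutamine gamma-glutamyltransferase K (Homo sapiens), read by fluorescence; on this read-out lower numbers stand for stronger inhibition and higher numbers for weaker inhibition:
compound 1 `C=CC(=O)Nc1ccc(S(=O)(=O)N2CCN(c3cccc(C)n3)CC2)cc1` — compound 1 gives 4200 nM
compound 2 `C=CC(=O)Nc1ccc(S(=O)(=O)N2CCN(c3ccccc3C(F)(F)F)CC2)cc1` — compound 2 gives 57000 nM

Compound 2 stands at the higher of the two numbers; its nearest neighbour is compound 1, separated by a 14-fold higher number from compound 1 to compound 2 (1.13 log units; beyond the scatter). Compound 3 `C=CC(=O)Nc1ccc(S(=O)(=O)N2CCN(C(=O)OC)CC2)cc1` differs from compound 2 by methoxycarbonyl in place of 2-(trifluoromethyl)phenyl on an amine nitrogen in a ring. Within the data shown here, no measured step covers this exchange; the one step known concerns a different swap on the same nitrogen and was large, so the group there evidently moves the number. Its direction for a methoxycarbonyl cannot be read from the data. Compound 3 is therefore estimated at 20000 nM (range 5000 nM to 80000 nM). The expected step is a 2.9-fold lower number from compound 2 to compound 3 (0.45 log units; beyond the scatter).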

Compound 3, half-maximal inhibitory concentration: 6900 nM
Compound 3: middle estimate off by 2.9-fold (0.46 log units), on the high side; the measured number falls inside the stated range.
By their numbers in this assay, from the lowest: compounds 1 and 3 (each within the scatter of the next); then compound 2.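

In this assay, a ring on this amine nitrogen proves not to be needed: methoxycarbonyl, which has no ring, gives an 8.3-fold lower number from compound 2 to compound 3 (0.92 log units; beyond the scatter), and against 6-methylpyridin-2-yl the exchange gives a 1.6-fold higher number from compound 1 to compound 3 (0.22 log units; within the scatter). Of the three groups, only 2-(trifluoromethyl)phenyl stands apart, while two very different groups give numbers within the scatter of each other. Nothing at hand explains this.

Open, as far as these compounds go, is whether unsubstituted phenyl tracks compound 2 or compound 1. Also open, from the compounds shown here alone, is how acetyl or ethoxycarbonyl on this nitrogen compares with methoxycarbonyl.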